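Bromo in place of trifluoromethyl: tolerability outlook

The source may hold more compounds than are shown below. What is called first, only, known or untested is meant among the compounds shown, and "the series" means these compounds.

The series shares one core, seen in compound 1 `COC(=O)c1cc(-c2cccc(NC(=O)c3ccc(/C=C/C(=O)c4ccccc4)cc3)c2)on1`, compound 2 `COC(=O)c1cc(-c2cccc(NC(=O)c3ccc(/C=C/C(=O)c4ccc(F)cc4)cc3)c2)on1` and compound 3 `COC(=O)c1cc(-c2cccc(NC(=O)c3ccc(/C=C/C(=O)c4cccc(C(F)(F)F)c4)cc3)c2)on1`. In an ADME assay on Vero cells (Chlorocebus sabaeus) for cytotoxicity, read by MTT assay, with a stated time of 72 h (a lower number here means that less compound is tolerated, a higher number that more compound is tolerated), compound 1 gives only a limit, > 50 ug/mL. In this assay compound 2 gives a limit, > 20 ug/mL. Compound 3 also stands at a limit, > 20 ug/mL, so it cannot be ranked against either neighbour. The steps a step that the two limits leave unreadable from compound 1 to compound 2, a step that the two limits leave unreadable from compound 1 to compound 3 and a step that the two limits leave unreadable from compound 2 to compound 3 are unreadable, as the limit of > 20 ug/mL in this assay, at which 2 of the 3 values shown sit, and the limit of > 50 ug/mL in this assay, at which 1 of the 3 values shown sits, show. Compound 4 `COC(=O)c1cc(-c2cccc(NC(=O)c3ccc(/C=C/C(=O)c4cccc(Br)c4)cc3)c2)on1` differs from compound 3 by bromo in place of trifluoromethyl on an aromatic carbon. Going by the values given here, no measured step bears on this change, and every value seen is a limit. Compound 4 is expected to be tolerated about as well as compound 3, with an estimated step that the limit leaves unreadable from compound 3 to compound 4 of no readable size. The estimate for compound 4 is 40 ug/mL, between 15 ug/mL and 100 ug/mL, most likely reported again as a limit.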

Compound 4, half-maximal cytotoxic concentration: > 100 ug/mL
Compound 4: no number, only a limit; the forecaster's own chance of this, stated with the estimate: 80%; at least 2.5-fold (0.39 log units) between middle value and limit.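

Compound 4 also gives only a limit, so its steps from compound 1, compound 2 and compound 3 cannot be read. The compounds shown leave open whether bromo or trifluoromethyl is better tolerated, and how the four compounds rank.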